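The source may hold more compounds than are shown below. What is called first, only, known or untested is meant among the compounds shown, and "the series" means these compounds.

Of the compounds shown here, three have been measured in a functional assay on cells (Cancer cell lines, Homo sapiens) for inhibition; a lower number here means a stronger inhibitor of growth, a higher number a weaker inhibitor of growth. Compound 1 `Cc1cn2c(/C=N/Nc3ccccn3)c(-c3ccc(Cl)c([N+](=O)[O-])c3)nc2s1` gives 7760 nM in this assay. Compound 2 `Cc1cn2c(/C=N/NC(=N)N)c(-c3ccsc3)nc2s1` gives 6920 nM. Compound 3 `N=C(N)N/N=C/c1c(-c2ccsc2)nc2sccn12` gives 15100 nM, the highest of the three numbers; the step of a 2.2-fold higher number from compound 2 to compound 3 (0.34 log units; beyond the scatter) lies beyond the scatter, while the gap between compound 3 and compound 1 stays within it, so those two cannot be ordered.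

Compound 4 `N=C(N)N/N=C/c1c(-c2cccs2)nc2sccn12` is the next one to be measured. It differs from compound 3 by thiophen-2-yl in place of thiophen-3-yl on an aromatic carbon. Among the compounds with values here, the only measured step, the hydrogen in place of methyl on an aromatic carbon between compound 2 and compound 3, concerns a different part of the shared core, and no measured pair shows the exchange of one thiophene attachment for the other. There is therefore nothing in the numbers to point to a step in either direction, and compound 4 is expected to sit about where compound 3 sits, the estimated step being a 1.1-fold lower number from compound 3 to compound 4 (0.03 log units; within the scatter). Compound 4 is estimated at 14000 nM, with a range from 5000 nM to 40000 nM.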

Compound 4, concentration for 50% growth inhibition: 12000 nM
Compound 4: the middle estimate sits 1.2-fold (0.07 log units) above what was measured; the range from low to high includes it.
By their numbers in this assay, from the lowest: compounds 2, 1, 4 and 3 (each within the scatter of the next, the first and the last beyond it).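

In this assay, thiophen-2-yl in place of thiophen-3-yl on an aromatic carbon gives a 1.3-fold lower number from compound 3 to compound 4 (0.10 log units; within the scatter), so the two thiophene attachments cannot be told apart at this position. Within the data shown here, this is the first measured change at this position, and it leaves the atom count of the group the same and alters only how the thiophene is joined to the shared core. No evidence on hand bears on why the two compounds read alike.

The compounds shown leave open whether the two attachments would also read alike with the methyl group of compound 2 on the shared core. They also leave open how a different ring at this position, such as furan-2-yl or an unsubstituted phenyl, would compare with either thiophene.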